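From 4-fluorophenyl to 3-(trifluoromethyl)phenyl on a sulfonyl sulfur

The source may hold more compounds than are shown below. What is called first, only, known or untested is meant among the compounds shown, and "the series" means these compounds.

Compound 1 (`CC(O)(CSc1ccccc1C(F)(F)F)C(=O)Nc1ccc(S(F)(F)(F)(F)F)cc1`) gives 13200 nM
Compound 2 (`CC(O)(CS(=O)(=O)c1ccc(S(F)(F)(F)(F)F)cc1)C(=O)Nc1ccc(S(F)(F)(F)(F)F)cc1`) gives 17300 nM
Compound 3 (`CC(O)(CS(=O)(=O)c1ccc(F)cc1)C(=O)Nc1ccc(S(F)(F)(F)(F)F)cc1`) gives 20600 nM

All three values come from a functional assay on CWR22R cells (Homo sapiens) for antiproliferative activity, read by propidium iodide staining, with a stated time of 96 h (on this read-out higher numbers stand for weaker inhibition and lower numbers for stronger inhibition), and sit close together. Compound 3, at 20600 nM, lies within the usual scatter of repeated measurements from both compound 1 and compound 2, so the numbers do not separate it from either.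

The next compound, compound 4 (`CC(O)(CS(=O)(=O)c1cccc(C(F)(F)F)c1)C(=O)Nc1ccc(S(F)(F)(F)(F)F)cc1`), carries 3-(trifluoromethyl)phenyl in place of 4-fluorophenyl on a sulfonyl sulfur. Going by the values given here, only one measured step also alters the group on that sulfonyl sulfur, and it is small (a 1.2-fold higher number from compound 2 to compound 3 (0.08 log units; within the scatter)). It is a single step and involves a different exchange, so it offers only limited guidance. Even so, no change beyond the scatter is expected in this assay, and the estimated step is correspondingly modest (a 1.3-fold lower number from compound 3 to compound 4 (0.11 log units; within the scatter)). Compound 4 is estimated at 16000 nM (expected range 7500 nM to 33000 nM).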

Compound 4, half-maximal inhibitory concentration: 23800 nM
Compound 4: the middle estimate sits 1.5-fold (0.17 log units) below what was measured; the measured number falls inside the stated range.
By their numbers in this assay, from the lowest: compounds 1, 2, 3 and 4 (each within the scatter of the next).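

In this assay, the exchange on the sulfonyl sulfur gives a 1.2-fold higher number from compound 3 to compound 4 (0.06 log units; within the scatter). This step replaces the whole aryl group, not just one substituent as the earlier step did, yet the two compounds still cannot be told apart, so this position has so far shown no sensitivity to either change. No measurement shown here offers an explanation for this flat result.

From the compounds shown here alone, it remains open whether any group at this position can move the number beyond the scatter, for example a phenyl ring carrying an amine or a carboxylic acid, or a saturated chain in place of the ring. The role of the sulfonyl itself is also unresolved, as compound 1 differs from the other compounds in more than one place.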